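This account rests on a few compounds, and the source may have more. Where it says the series, first, only, none or still open, it means among the compounds named here.

Compound 1, `Cc1cn2c(/C=N/NC(=N)N)c(-c3ccncc3)nc2s1`, in a functional assay on NSCLC cells (Homo sapiens) for antiproliferative activity (a higher number here means a weaker inhibitor of growth, a lower number a stronger inhibitor of growth), compound 1 gives 16600 nM. Compound 2, `Cc1sc2nc(-c3ccncc3)c(/C=N/NC(=N)N)n2c1C`, in this assay compound 2 gives 38900 nM.

Within the data shown here, compound 1 holds the lower of the two numbers, and the only measured step is a 2.3-fold higher number from compound 1 to compound 2 (0.37 log units; beyond the scatter). Compound 3, `Cc1cn2c(/C=N/NC(=N)N)c(-c3cccnc3)nc2s1`, differs from compound 1 by pyridin-3-yl in place of pyridin-4-yl on an aromatic carbon. Among the measured compounds shown here, no measured step changes the pyridin-4-yl group; the one measured step adds a methyl elsewhere and does not bear on this change. For compound 3 the expected step is a 1.0-fold lower number from compound 1 to compound 3 (0.02 log units; within the scatter), not beyond the scatter. Compound 3 is estimated at 16000 nM, with an expected range from 5000 nM to 50000 nM.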

Compound 3, concentration for 50% growth inhibition: 13800 nM
Compound 3: the middle estimate sits 1.2-fold (0.06 log units) above what was measured, and the stated range covers the measured number.
By their numbers in this assay, from the lowest: compounds 3 and 1 (each within the scatter of the next); then compound 2.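

Putting pyridin-3-yl in place of pyridin-4-yl gives a 1.2-fold lower number from compound 1 to compound 3 (0.08 log units; within the scatter) in this assay. Among these compounds, this is the first look at this position, and moving the nitrogen around the pyridine ring leaves growth inhibition indistinguishable from the scatter. Nothing available explains why the two groups read alike.

Both groups are pyridines, so a plain phenyl or a pyridin-2-yl would be needed to show whether the ring nitrogen matters at all. On these data alone, whether pyridin-3-yl behaves the same alongside the extra methyl of compound 2 also stays open.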